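A few compounds are considered here, and "the series" means these few. Any claim that something is new, unique, unknown or untested is made for them only; others in the source may bear on it.

Three thiosemicarbazide derivatives of a shared core were examined in a functional assay on HeLa cells (Homo sapiens) for cytotoxicity, read by MTT assay, with a stated time of 72 h, tested at 100 uM; on this read-out lower numbers stand for less inhibition of growth and higher numbers for more inhibition of growth at the one concentration tested. Compound 1, `Cc1ccnc(/C(N)=N/NC(=S)N2CCCC2)c1`, gives 88.1% in this assay. Compound 2, `N/C(=N\NC(=S)N1CCSCC1)c1ccccn1`, gives 88.7%. Compound 3, `N/C(=N\NC(=S)N1CCOCC1)c1ccc(F)cn1`, gives 81.2%. Compound 3 thus gives the lowest of the three numbers, yet neither of the other two sits beyond the scatter from it: compound 1 lies closest, and compound 2 furthest, and both gaps stay within the scatter of repeated measurements. On the numbers shown, the three compounds are therefore indistinguishable in this assay.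

The next compound, compound 4, `N/C(=N\NC(=S)N1CCOCC1)c1ccccn1`, has not yet been measured. It differs from compound 3 in one place: hydrogen in place of fluoro on an aromatic carbon. Among the compounds with values here, no step between two measured compounds of this set changes only that place, so nothing in the data shows what such a change does here. Given that all three measured compounds fall within the scatter of one another, the expected step of a number 2.8 percentage points higher from compound 3 to compound 4 (within the scatter) stays within the scatter, with no direction favored. Compound 4 is accordingly expected to give about 84% in this assay, with a range from 70% to 95%.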

Compound 4, percent growth inhibition at one concentration: 87.2%
Beside the measured number, compound 4's estimate is 3.2 percentage points below it; measured number inside the range.
By their numbers in this assay, from the lowest: compounds 3, 4, 1 and 2 (each within the scatter of the next).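

Read in this assay, the change of hydrogen in place of fluoro on an aromatic carbon, para to a large group and two atoms from the ring nitrogen, gives a number 6 percentage points higher from compound 3 to compound 4 (within the scatter) and is the first direct look at this position, showing that at the one concentration tested the read-out does not depend on the fluoro group there. The change of morpholin-4-yl in place of thiomorpholin-4-yl on a thiocarbonyl carbon gives a number 1.5 percentage points lower from compound 2 to compound 4 (within the scatter) and likewise shows no effect that can be told from the scatter, so neither of the two single changes separates the compounds it connects. No measurement shown here offers a reason for either result.

The compounds shown leave open whether another group at this aromatic carbon, such as chloro, methoxy, an amine or a carboxylic acid, would carry the number beyond the scatter. They also leave open whether the two changes would stay without effect at a concentration lower than the one tested, where compounds that look alike here might come apart.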